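The source may report more compounds than this note shows. Statements on the series, on what has been measured and on what is new or still open speak of the compounds shown alone.

Two azido nucleosides sharing a sugar portion have been measured in an ADME assay on PBMC cells (Homo sapiens) for cytotoxicity, with a stated time of 5 days; a lower number here means a stronger inhibitor, a higher number a weaker inhibitor. In this assay, compound 1 `COc1nc(F)nc2c1ncn2[C@H]1C[C@H](N=[N+]=[N-])[C@@H](CO)O1` gives 9400 nM, and compound 2 `COc1nc(N)c2ncn([C@H]3C[C@H](N=[N+]=[N-])[C@@H](CO)O3)c2n1` gives 35000 nM. Compound 2 therefore holds the higher of the two numbers, making it the weaker inhibitor of the pair, and the gap between them lies beyond the scatter of repeated measurements.

The next compound to be tested is compound 3 `[N-]=[N+]=N[C@H]1C[C@H](n2cnc3c(N)nc(F)nc32)O[C@@H]1CO`. It departs from compound 2 by one change, fluoro in place of methoxy on an aromatic carbon, between two ring nitrogen atoms: fluoro in place of methoxy on an aromatic carbon. Among the compounds with values here, no measured pair isolates this change, so the size of the step cannot be read directly from the data. Within the data shown here, the only guide is compound 1, which carries a fluoro group and gives 9400 nM in this assay. This suggests a move toward the lower number, though on thin evidence. What is expected is a 3.5-fold lower number from compound 2 to compound 3 (0.54 log units; beyond the scatter), a decrease that would lie beyond the scatter. For compound 3 the estimated value is 10000 nM, with an expected range from 2500 nM to 40000 nM.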

Compound 3, half-maximal inhibitory concentration: 30100 nM
For compound 3 the middle estimate is 3.0-fold (0.48 log units) below the measured one; the range from low to high includes it.
By their numbers in this assay, from the lowest: compound 1; then compounds 3 and 2 (each within the scatter of the next).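

In this assay, fluoro in place of methoxy on an aromatic carbon between two ring nitrogen atoms gives a 1.2-fold lower number from compound 2 to compound 3 (0.07 log units; within the scatter), so at this position the two groups cannot be told apart. The fluoro group therefore does not by itself go with the lower number seen earlier: with the fluoro group kept, exchanging methoxy for amino gives a 3.2-fold higher number from compound 1 to compound 3 (0.51 log units; beyond the scatter), a modest step that is the only one of the two to lie beyond the scatter. The data shown offer nothing that would explain either step.

Among the compounds shown, only methoxy and fluoro occupy the position between two ring nitrogen atoms, so it remains open whether a chloro group, a hydroxyl or an amine such as methylamino there would leave the number in the same range or move it. On these data alone, the amino-for-methoxy step rests on a single pair, and whether a methylamino or an ethoxy group in that same place would give a step of similar size also stays open.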